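The compounds below may be only part of what the source reports. "The series", "measured", "known", "first", "only" and "open" are said of these compounds alone.

Working notes on the series. Compound 1 `O=C(O)CCCCCCNS(=O)(=O)c1ccccc1` is the shortest member. In a functional assay for inhibition, with Oryctolagus cuniculus as the target (a higher number here means a weaker inhibitor, a lower number a stronger inhibitor), compound 1 gives only a limit, > 10000 nM, so its actual number is not known (the limit of > 10000 nM in this assay, at which 1 of the 2 values shown sits). Compound 2 `O=C(O)CCCCCCCNS(=O)(=O)c1ccccc1` carries one more chain carbon; in this assay compound 2 gives 700 nM, which makes the step of an at least 14-fold lower number from compound 1 to compound 2 (1.15 log units; beyond the scatter) large and beyond the scatter, toward a stronger inhibitor. Compound 3 `O=C(O)CCCCCCCCNS(=O)(=O)c1ccccc1` has not yet been measured; against compound 1 the change is 2-carboxyethyl in place of carboxy on a saturated chain carbon, six bonds along the chain from a sulfonamide nitrogen. Within the data shown here, the only measured step that bears on it is an at least 14-fold lower number from compound 1 to compound 2 (1.15 log units; beyond the scatter), the same kind of change taken one carbon less far, and it was large and downward. A step of comparable size in the same direction is therefore expected, an at least 25-fold lower number from compound 1 to compound 3 (1.39 log units; beyond the scatter), with the open question being whether the second added carbon adds further or merely holds the gain. Compound 3 is accordingly expected to give 400 nM in this assay, within 60 nM to 3000 nM.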

Compound 3, half-maximal inhibitory concentration: 400 nM
For compound 3 middle estimate and measured number coincide at the digits printed; the measured number falls inside the stated range.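

The new point lies beyond compound 2. In this assay, lengthening the chain again gives a 1.8-fold lower number from compound 2 to compound 3 (0.24 log units; within the scatter), so the second added carbon cannot be told apart from the first in its effect on this read-out. The full change to 2-carboxyethyl gives an at least 25-fold lower number from compound 1 to compound 3 (1.39 log units; beyond the scatter), which shows the large gain held at the longer length, with no further gain that can be read. Compound 1 is a limit and not a number: the limit of > 10000 nM in this assay, at which 1 of the 3 values shown sits.

From the compounds shown here alone, whether a longer chain than that of compound 3 keeps this level or loses it remains open. So does whether a primary amide or a tetrazole at the chain end, in place of the carboxylic acid, would hold it.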